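Replacing 2-Phenylethenyl with 3,4-Dimethoxyphenyl on the Shared Core

The source may report more compounds than this note shows. Statements on the series, on what has been measured and on what is new or still open speak of the compounds shown alone.

Compound 1 `Cc1cc(O)c(C2=NN(c3ccc(S(N)(=O)=O)cc3)C(c3ccccc3O)C2)cc1Cl`: 51900 nM
Compound 2 `Cc1cc(O)c(C2=NN(c3ccc(S(N)(=O)=O)cc3)C(/C=C/c3ccccc3)C2)cc1Cl`: 46700 nM

Both compounds were tested in a functional assay on SF-268 cells (Homo sapiens) for antiproliferative activity, with a stated time of 48 h; on this read-out higher numbers stand for lower toxicity in this test and lower numbers for higher toxicity in this test. Among the compounds with values here, the one change between them, a 1.1-fold lower number from compound 1 to compound 2 (0.05 log units; within the scatter), shows that compound 1 and compound 2 sit within the scatter of each other; on the two numbers available, compound 2 is simply one of two values that cannot be told apart.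

Compound 3 `COc1ccc(C2CC(c3cc(Cl)c(C)cc3O)=NN2c2ccc(S(N)(=O)=O)cc2)cc1OC` has not yet been measured in this assay. It differs from compound 2 in one place: 3,4-dimethoxyphenyl in place of 2-phenylethenyl on a saturated ring carbon. Within the data shown here, the only measured step on this position is the one from compound 1 to compound 2, which swapped the same saturated ring carbon's aryl group and gave no change beyond the scatter. On that basis, another swap at the same place is expected to leave the number about where compound 2 stands, with a 1.0-fold higher number from compound 2 to compound 3 (0.01 log units; within the scatter) expected to stay inside the scatter. Compound 3 is therefore estimated at 48000 nM, with a range from 20000 nM to 115000 nM.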

Compound 3, concentration lethal to 50% of the cells: > 100000 nM
Compound 3: only a limit was reported; the forecaster's own chance of this, stated with the estimate: 10%; middle value at least 2.0-fold (0.31 log units) from the limit.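

The saturated ring carbon is not indifferent to the group it carries: in this assay, 3,4-dimethoxyphenyl in place of 2-phenylethenyl gives an at least 2.1-fold higher number from compound 2 to compound 3 (0.33 log units; beyond the scatter), which here means lower toxicity. The comparison with 2-hydroxyphenyl is less firm: an at least 1.9-fold higher number from compound 1 to compound 3 (0.28 log units; that floor lies within the scatter) is all that can be read, so compound 3 is not shown to differ from compound 1. Compound 3 has only a limit rather than a number, so the full size of both steps remains unknown: the limit of > 100000 nM in this assay, at which 1 of the 3 values shown sits.

The compounds shown do not separate the contribution of the two methoxy groups from that of the aromatic ring itself, as no phenyl carrying just one methoxy group appears among them. From the compounds shown here alone, it also remains open how this position would respond to a phenyl ring bearing an amine or a carboxylic acid.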